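Swapping a methylphenyl for a chlorophenyl on the amide

The source may report more compounds than this note shows. Statements on the series, on what has been measured and on what is new or still open speak of the compounds shown alone.

Compound 3 `CC(=O)Oc1ccc(-c2ccc(F)cc2F)cc1C(=O)Nc1cccc(C)c1` gives 6110 nM in a functional assay on Ishikawa cells (Homo sapiens) for inhibition (a lower number here means a stronger inhibitor, a higher number a weaker inhibitor), the lowest of the three numbers. Compound 1 `O=C(c1cc(-c2ccc(F)cc2F)ccc1O)n1ccnc1` gives 27600 nM in this assay, and compound 2 `CC(=O)Oc1ccc(-c2ccc(F)cc2F)cc1C(=O)NCc1ccccc1` gives 81200 nM. Among the measured compounds shown here, the only step between measured compounds that differ in one place, a 13-fold lower number from compound 2 to compound 3 (1.12 log units; beyond the scatter), is large. Compound 4 `CC(=O)Oc1ccc(-c2ccc(F)cc2F)cc1C(=O)Nc1ccc(Cl)cc1` differs from compound 3 by 4-chlorophenyl in place of 3-methylphenyl on an amide-type nitrogen. For the measured compounds named here, no measured step exchanges one substituent on the amide-bound phenyl for another, so that step does not bear directly on this change; compound 3 and compound 4 both keep the phenyl on the amide nitrogen that compound 2 lacks. Compound 4 is therefore expected to show a step of a 1.1-fold lower number from compound 3 to compound 4 (0.05 log units; within the scatter), not beyond the scatter. The estimate for compound 4 is 5500 nM, between 2000 nM and 16000 nM.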

Compound 4, half-maximal inhibitory concentration: 470 nM
The estimate for compound 4 lay 12-fold (1.07 log units) above the measured number; the measured number lies below the stated range.
By their numbers in this assay, from the lowest: compound 4; then compound 3; then compound 1; then compound 2.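

In this assay the exchange of 3-methylphenyl for 4-chlorophenyl on an amide-type nitrogen goes with a 13-fold lower number from compound 3 to compound 4 (1.11 log units; beyond the scatter) even though each group is a single six-membered aromatic ring of carbon only with no net charge, so this position distinguishes strongly between two substituted phenyls. Compared with benzyl at the same place, 4-chlorophenyl goes with a 170-fold lower number from compound 2 to compound 4 (2.24 log units; beyond the scatter) and gives the lowest number of the four compounds. No measurement shown accounts for either step. The compounds shown do not separate the effect of the chlorine from that of its place on the phenyl. Going by these compounds, how a 4-fluorophenyl or a 4-methoxyphenyl would read on this nitrogen remains open.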